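This account rests on a few compounds, and the source may have more. Where it says the series, first, only, none or still open, it means among the compounds named here.

Compound 1 `CCCN(CCC)C[C@@H](C)NC(=O)c1ccc(-c2ncon2)cc1` is the starting point. In an assay on isolated protein for inhibition of histone deacetylase 4 (Homo sapiens), read by fluorescence (a higher number here means a weaker inhibitor, a lower number a stronger inhibitor), compound 1 gives only a limit, > 50000 nM, which is the limit of > 50000 nM in this assay, at which 1 of the 3 values shown sits. Two other compounds carry 3-(trifluoromethyl)-1,2,4-oxadiazol-5-yl: compound 2 `C[C@H](CN1CCC(F)(F)CC1)NC(=O)c1ccc(-c2noc(C(F)(F)F)n2)cc1` gives 130 nM in this assay, and compound 3 `O=C(NC1(CN2CCCC2)CC1)c1ccc(-c2noc(C(F)(F)F)n2)cc1` gives 40 nM. Compound 4 `CCCN(CCC)C[C@@H](C)NC(=O)c1ccc(-c2nc(C(F)(F)F)no2)cc1` has not yet been measured. It differs from compound 1 in one place: 3-(trifluoromethyl)-1,2,4-oxadiazol-5-yl in place of 1,2,4-oxadiazol-3-yl on an aromatic carbon. Going by the values given here, no measured pair isolates this change, and compounds 2 and 3 differ from compound 1 elsewhere as well. Still, both compounds bearing that ring inhibit clearly in this assay, whereas compound 1 does not, so the step from compound 1 to compound 4 is expected to be large toward stronger inhibition, an at least 200-fold lower number from compound 1 to compound 4 (2.30 log units; beyond the scatter). Compound 4 is estimated at 250 nM, between 50 nM and 2000 nM.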

Compound 4, half-maximal inhibitory concentration: 28000 nM
For compound 4 the middle estimate is 110-fold (2.05 log units) below the measured one, outside the stated range (above it).
By their numbers in this assay, from the lowest: compound 3; then compound 2; then compound 4. At a limit, above all of these: compound 1.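

In this assay, 3-(trifluoromethyl)-1,2,4-oxadiazol-5-yl in place of 1,2,4-oxadiazol-3-yl on this aromatic carbon gives an at least 1.7-fold lower number from compound 1 to compound 4 (0.25 log units; that floor lies within the scatter). That step is only a floor, because compound 1 stands at a limit of the assay: the limit of > 50000 nM in this assay, at which 1 of the 4 values shown sits.

Carrying this ring does not by itself bring compound 4 to the level of compound 2 and compound 3, whose numbers are both lower. The compounds shown leave open how much of that gap lies in the amine side chain, and whether a morpholine there or a hydroxamic acid in place of the ring would lower the number further.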